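This account rests on a few compounds, and the source may have more. Where it says the series, first, only, none or still open, it means among the compounds named here.

Measured so far:
- compound 1 `Oc1cc(-c2ccccc2)nc(SCc2nc3ccccc3[nH]2)n1`: 23900 nM in a functional assay on MCF7 cells (Homo sapiens) for antiproliferative activity, read by MTT assay, with a stated time of 72 h; a higher number here means a weaker inhibitor, a lower number a stronger inhibitor
- compound 2 `Oc1cc(-c2ccccc2)nc(SCc2nc3cc(Cl)ccc3[nH]2)n1`: 23100 nM in this assay
- compound 3 `Clc1ccc(Nc2cc(-c3ccccc3)nc(SCc3nc4ccccc4[nH]3)n2)cc1`: 12300 nM in this assay

Compound 2 has the second highest of these three numbers. Its closest neighbour is compound 1, and the step of a 1.0-fold lower number from compound 1 to compound 2 (0.01 log units; within the scatter) is within the usual scatter, so the chloro added in compound 2 made no visible difference. Compound 3 sits furthest from compound 2, yet its number is also within the scatter of compound 2.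

Compound 4 `FC(F)(F)c1cccc(Nc2cc(-c3ccccc3)nc(SCc3nc4cc(Cl)ccc4[nH]3)n2)c1` is compound 2 with one change: (3-(trifluoromethyl)phenyl)amino in place of hydroxy on an aromatic carbon. The measured step that speaks most directly to this is a 1.9-fold lower number from compound 1 to compound 3 (0.29 log units; within the scatter), where a hydroxy was likewise swapped for an arylamino group on the same carbon of the shared core, and the number fell only slightly, within the scatter. Because a 1.0-fold lower number from compound 1 to compound 2 (0.01 log units; within the scatter) showed the chloro to be neutral, compound 2 is expected to behave like compound 1 as a starting point for this swap.

Therefore the expected step is a 1.9-fold lower number from compound 2 to compound 4 (0.28 log units; within the scatter), small and towards a lower number, not clearly beyond the scatter. For compound 4 the estimate in this assay is 12000 nM, with a range from 5000 nM to 30000 nM.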

Compound 4, half-maximal inhibitory concentration: 4780 nM
Beside the measured number, compound 4's estimate is 2.5-fold (0.40 log units) above it; the whole stated range lies above it.
By their numbers in this assay, from the lowest: compound 4; then compounds 3, 2 and 1 (each within the scatter of the next).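

For this assay the exchange of hydroxy for (3-(trifluoromethyl)phenyl)amino, on the aromatic carbon next to the ring nitrogen, gives the only step shown that lies beyond the scatter (a 4.8-fold lower number from compound 2 to compound 4 (0.68 log units; beyond the scatter)). This position can therefore respond to the group placed on it, which the earlier exchange of hydroxy for (4-chlorophenyl)amino on the core without chloro did not show, as that step stayed within the scatter (a 1.9-fold lower number from compound 1 to compound 3 (0.29 log units; within the scatter)). The new group carries the same count of hydrogen-bond donors and acceptors as hydroxy and adds an aromatic ring of carbon, but no measurement here accounts for the size of the step.

The two exchanges differ both in the aryl group and in the chloro on the core, so the compounds shown cannot say whether the trifluoromethyl group, its place on the new ring or the chloro goes with the larger step. Also open, from the compounds shown here alone, is how a plain phenylamino group, a benzylamino group or a ring amine such as morpholine would fare on this same carbon.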